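Isobutyl for Isopropyl in a Cytotoxicity Series

The source may report more compounds than this note shows. Statements on the series, on what has been measured and on what is new or still open speak of the compounds shown alone.

Compound 3 `COc1cc(NC(C)CCCN2C(=O)CN(C(=O)[C@H](N)C(C)C)C2(C)C)c2ncccc2c1` is one of three analogues on a shared core tested in an ADME assay on A549 cells (Homo sapiens) for cytotoxicity, with a stated time of 72 h; a higher number here means a weaker inhibitor, a lower number a stronger inhibitor. Compound 3 gives 5500 nM, the lower of the two numbers shown, with compound 1 within the scatter of it. Compound 1 `COc1cc(NC(C)CCCN2C(=O)CN(C(=O)[C@H](N)CCSC)C2(C)C)c2ncccc2c1` gives 7900 nM. Compound 2 `COc1cc(N(C(C)=O)C(C)CCCN2C(=O)CN(C(C)=O)C2(C)C)c2ncccc2c1` gives only a limit, > 100000 nM, which is the limit of > 100000 nM in this assay, at which 1 of the 3 values shown sits. Compound 4 `COc1cc(NC(C)CCCN2C(=O)CN(C(=O)[C@H](N)CC(C)C)C2(C)C)c2ncccc2c1` differs from compound 3 by isobutyl in place of isopropyl on a saturated chain carbon bound to an amine nitrogen and a carbonyl carbon. Among the compounds with values here, the only measured change at the same place is a 1.4-fold lower number from compound 1 to compound 3 (0.16 log units; within the scatter). Because a 1.4-fold lower number from compound 1 to compound 3 (0.16 log units; within the scatter) lies within the scatter, no movement beyond the scatter is expected in this assay, and the estimated step of a 1.2-fold lower number from compound 3 to compound 4 (0.09 log units; within the scatter) is small. Compound 4 is therefore expected to give about 4500 nM, within 2000 nM to 12000 nM.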

Compound 4, half-maximal inhibitory concentration: 21200 nM
The estimate for compound 4 lay 4.7-fold (0.67 log units) below the measured number; the whole stated range lies below it.
By their numbers in this assay, from the lowest: compounds 3 and 1 (each within the scatter of the next); then compound 4. At a limit, above all of these: compound 2.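

The place on a saturated chain carbon bound to an amine nitrogen and a carbonyl carbon proved sensitive to its group, which the earlier pair had not shown: the change to isobutyl gives a 3.9-fold higher number from compound 3 to compound 4 (0.59 log units; beyond the scatter). The same compound also stands apart from the methylsulfanyl-bearing analogue, with a 2.7-fold higher number from compound 1 to compound 4 (0.43 log units; beyond the scatter), so isobutyl separates from both earlier groups. Nothing measured here accounts for this step. From the compounds shown here alone, whether a longer unbranched chain, a benzyl group or a carboxylic acid at this place would raise the number further remains open.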